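The compounds below may be only part of what the source reports. "The series", "measured", "known", "first", "only" and "open" are said of these compounds alone.

Compound 1 `CCN1C(=O)C(O)(Cc2nnn[nH]2)c2cc(Cl)ccc21` in a functional assay on BT-549 cells (Homo sapiens) for antiproliferative activity, read by MTT assay, with a stated time of 48 h (on this read-out lower numbers stand for stronger inhibition and higher numbers for weaker inhibition), gives 85400 nM. Compound 2 `CCN1C(=O)C(O)(Cc2nnn[nH]2)c2cc(Br)ccc21` reaches only the limit of this assay, > 100000 nM. The step of an at least 1.1-fold higher number from compound 1 to compound 2 (0.06 log units; that floor lies within the scatter) is bounded by the limit of > 100000 nM in this assay, at which 1 of the 2 values shown sits, so compound 2 stands at the weak end of the two values shown, with no number of its own. Compound 3 `CCN1C(=O)C(O)(Cc2nnn[nH]2)c2cc(C)ccc21` carries the change (methyl in place of bromo on an aromatic carbon). Among the measured compounds shown here, no measured step involves a methyl group; the one step known, the halogen swap, stayed within the scatter. Compound 3 is therefore expected to show a number no higher from compound 2 to compound 3 (the limit leaves the size open), no shift beyond the scatter. For compound 3 the estimate is 100000 nM, between 40000 nM and 300000 nM.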

Compound 3, half-maximal inhibitory concentration: > 100000 nM
Compound 3 was reported as a limit; the forecaster's own chance of this, stated with the estimate: 55%; the middle value sits exactly at the limit.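

Among the compounds shown here, compound 3 gives a limit and not a number, so methyl on this aromatic carbon, the first group here that is not a halogen, also yields no readable value in this assay. Against chloro, the change gives an at least 1.1-fold higher number from compound 1 to compound 3 (0.06 log units; that floor lies within the scatter), and the step between the two limits cannot be read. Any order among bromo, methyl and chloro at this position therefore stays hidden: the limit of > 100000 nM in this assay, at which 2 of the 3 values shown sit.

As far as these compounds go, whether an amine or a carboxylic acid on this aromatic carbon would bring a value clearly apart from compound 1 remains open.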